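This account rests on a few compounds, and the source may have more. Where it says the series, first, only, none or still open, it means among the compounds named here.

Measured so far:
compound 1, `COc1cc(-c2cc(/C=C/C(=O)c3ccc(N)cc3)[nH]n2)cc(OC)c1OC`, -66%
compound 2, `COc1cc(-c2cc(/C=C/C(=O)c3ccc(Cl)c(Cl)c3)[nH]n2)cc(OC)c1OC`, 65%

In a functional assay on OVCAR-5 cells (Homo sapiens) for cytotoxicity, read by sulforhodamine B assay, with a stated time of 48 h, tested at 10 uM (on this read-out lower numbers stand for a stronger effect and higher numbers for a weaker effect at the one concentration tested), compound 1 gives -66%, the lowest of the two numbers measured, and its nearest neighbour is compound 2, which gives 65%. Within the data shown here, the single measured step, 3,4-dichlorophenyl in place of 4-aminophenyl on a carbonyl carbon, is a number 131 percentage points higher from compound 1 to compound 2 (beyond the scatter).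

Compound 3, `COc1cc(-c2cc(/C=C/C(=O)c3ccc(F)c(F)c3)[nH]n2)cc(OC)c1OC`, is not yet measured. It differs from compound 1 as follows:
3,4-difluorophenyl in place of 4-aminophenyl on a carbonyl carbon

Among the measured compounds shown here, the only step that bears on this change is the one from compound 1 to compound 2, where a different halogenated phenyl also replaced the 4-aminophenyl on the carbonyl carbon, and it was large and upward. Compound 3 is therefore expected to move in the same direction, with a step of about a number 106 percentage points higher from compound 1 to compound 3 (beyond the scatter), though a somewhat smaller one than seen with compound 2 cannot be excluded. For compound 3 the expected value in this assay is 40%, within a range of -10% to 80%.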

Compound 3, a percentage reported as activity, at one concentration (the size of the read-out at that concentration, not a potency): 27%
Beside the measured number, compound 3's estimate is 13 percentage points above it; measured number inside the range.
By their numbers in this assay, from the lowest: compound 1; then compound 3; then compound 2.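

In this assay, a second dihalogenated phenyl on the carbonyl carbon also gives a large upward change, a number 93 percentage points higher from compound 1 to compound 3 (beyond the scatter), so this loss of effect is not particular to 3,4-dichlorophenyl. The choice of halogen matters here too, with a number 38 percentage points lower from compound 2 to compound 3 (beyond the scatter), yet 3,4-difluorophenyl still leaves compound 3 well short of compound 1 in this read-out. No measurement on these compounds accounts for this order.

The compounds shown leave open whether the amino group itself sets compound 1 apart, or whether a 4-hydroxyphenyl or 4-methoxyphenyl on the carbonyl carbon would also give a low number. They also leave open how a phenyl carrying a single fluorine or a single chlorine would compare with the two dihalogenated phenyls.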